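Extending the ether chain on the shared core: compound 3 to compound 4

The source may hold more compounds than are shown below. What is called first, only, known or untested is meant among the compounds shown, and "the series" means these compounds.

The three measured compounds share one core and differ only in the group attached through an oxygen on an aromatic ring. In a functional assay on CHO cells for antagonist activity at sphingosine 1-phosphate receptor 2 (Homo sapiens), read by calcium flux (a higher number here means a weaker inhibitor, a lower number a stronger inhibitor), compound 1 `O=C(O)Cn1nc(Cc2nc3cc(Cl)c(OC(F)(F)F)cc3[nH]2)c2ccccc2c1=O` gives 31 nM, compound 2 `CCOc1cc2[nH]c(Cc3nn(CC(=O)O)c(=O)c4ccccc34)nc2cc1Cl` gives 17 nM, and compound 3 `COc1cc2[nH]c(Cc3nn(CC(=O)O)c(=O)c4ccccc34)nc2cc1Cl` gives 61 nM. Compound 3 thus stands with the highest number of the three, close to compound 1 but clearly separated from compound 2, as the step of a 3.6-fold higher number from compound 2 to compound 3 (0.55 log units; beyond the scatter) shows.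

Compound 4 `O=C(O)Cn1nc(Cc2nc3cc(Cl)c(OCC4CC4)cc3[nH]2)c2ccccc2c1=O` takes the change (cyclopropyl in place of hydrogen on a saturated chain carbon bound to an oxygen on an aromatic ring). Going by the values given here, the one measured step that bears on this place is a 3.6-fold higher number from compound 2 to compound 3 (0.55 log units; beyond the scatter), where removing a carbon from the chain raised the number beyond the scatter. Compound 4 goes the other way and adds a ring to the same carbon, so a lower number than that of compound 3 is expected, by about a 5.1-fold lower number from compound 3 to compound 4 (0.71 log units; beyond the scatter). For compound 4 the value in this assay is estimated at 12 nM, with a range from 4 nM to 35 nM.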

Compound 4, half-maximal inhibitory concentration: 8.8 nM
Estimate against measurement, compound 4: 1.4-fold (0.13 log units) above; the measured number falls inside the stated range.
By their numbers in this assay, from the lowest: compounds 4, 2, 1 and 3 (each within the scatter of the next, the first and the last beyond it).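

Carrying a cyclopropyl ring on the ether chain is well tolerated at this position in this assay. There is a 6.9-fold lower number from compound 3 to compound 4 (0.84 log units; beyond the scatter) and also a 3.5-fold lower number from compound 1 to compound 4 (0.55 log units; beyond the scatter), so the group on the oxygen can grow from methyl to cyclopropylmethyl with no loss of inhibition, while a 1.9-fold lower number from compound 2 to compound 4 (0.29 log units; within the scatter) means that cyclopropyl in place of the methyl of the ethyl group brings no measurable difference. Nothing shown here explains these differences.

The compounds shown leave open whether the ring itself matters, or whether an open chain such as propyl or butyl would give a similar number. On these data alone, it also remains open how far this carbon can be extended, for instance with a larger ring such as cyclohexyl, or with an amine on the chain.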